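Working Notes: Carbamate Series, Cell Growth Inhibition

The source may hold more compounds than are shown below. What is called first, only, known or untested is meant among the compounds shown, and "the series" means these compounds.

Measured so far:
Compound 1, `CC(C)COC(=O)Nc1ccc([Se][Se]c2ccc(NC(=O)OCC(C)C)cc2)cc1`, 13100 nM
Compound 2, `C=CCOC(=O)Nc1ccc([Se]C#N)cc1`, 21400 nM
Compound 3, `O=C(Nc1ccc([Se][Se]c2ccc(NC(=O)OCc3ccc([N+](=O)[O-])cc3)cc2)cc1)OCc1ccc([N+](=O)[O-])cc1`, 6300 nM

In an ADME assay on BEAS-2B cells (Homo sapiens) for cytotoxicity, read by MTT assay, with a stated time of 72 h (on this read-out higher numbers stand for weaker inhibition of growth and lower numbers for stronger inhibition of growth), three compounds carry numbers. Compound 1 gives 13100 nM, compound 3 gives 6300 nM, and compound 2 gives 21400 nM. Compound 2 holds the highest number of the three. Its nearest neighbour is compound 1, and that gap sits within the usual scatter, so no order between compound 2 and compound 1 can be read from it. The gap to compound 3 lies beyond the scatter, and on this read-out compound 3 shows the stronger inhibition of growth of that pair.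

Compound 4, `CCOC(=O)Nc1ccc([Se]C#N)cc1`, has not been measured. It differs from compound 2 in one place: methyl in place of vinyl on a saturated chain carbon bound to an oxygen next to a carbonyl group. Among the compounds with values here, no step between two measured compounds matches this change, so the expectation rests on the change itself. Compound 4 is expected to stay close to compound 2, with the step of a 1.1-fold lower number from compound 2 to compound 4 (0.03 log units; within the scatter) expected to fall within the scatter and in no settled direction. On that basis compound 4 is estimated at 20000 nM, within a range from 9000 nM to 45000 nM.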

Compound 4, concentration for 50% growth inhibition: 21700 nM
The estimate for compound 4 lay 1.1-fold (0.04 log units) below the measured number; the range from low to high includes it.
By their numbers in this assay, from the lowest: compound 3; then compounds 1, 2 and 4 (each within the scatter of the next).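

Working notes, continued. In this assay, within the data shown here, methyl in place of vinyl on a saturated chain carbon bound to an oxygen next to a carbonyl group gives a 1.0-fold higher number from compound 2 to compound 4 (0.01 log units; within the scatter), the only step that can be read at a single place. Compounds 1 and 3 could not speak to this position, since each differs from compound 2 in more than one place, whereas this pair shows that the read-out does not separate allyl from ethyl, even though the change removes the double bond outside aromatic rings and one carbon. Nothing measured on this pair speaks to the reason for that result.

The steps from compound 1 or compound 3 to the other compounds cannot be read, so the contribution of the selenium-bearing end of the structure and of the carbamate end remain tangled together. Going by these compounds, whether this position stays equally undiscriminating with a longer chain such as hexyl, or with an amine or a carboxylic acid at the chain end, remains open.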